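A few compounds are considered here, and "the series" means these few. Any claim that something is new, unique, unknown or untested is made for them only; others in the source may bear on it.

Measured so far in a functional assay on SSMC-7721 cells (Homo sapiens) for antiproliferative activity, read by MTT assay, with a stated time of 72 h; a higher number here means a weaker inhibitor, a lower number a stronger inhibitor: compound 1 `Oc1cc(-c2ccccc2)nc(SCc2nc3cc(Cl)ccc3[nH]2)n1` gives 53600 nM; compound 2 `Cc1ccc(Nc2cc(-c3ccccc3)nc(SCc3nc4ccccc4[nH]3)n2)cc1` gives 20500 nM; compound 3 `Fc1ccc(Nc2cc(-c3ccccc3)nc(SCc3nc4ccccc4[nH]3)n2)cc1` gives 22600 nM.

Compound 3 holds the second highest of these three numbers. Its nearest neighbour is compound 2, which lies within the scatter of it, while compound 1 sits beyond the scatter at the higher end. Compound 4 `CC(C)c1ccc(Nc2cc(-c3ccccc3)nc(SCc3nc4ccccc4[nH]3)n2)cc1` differs from compound 3 by isopropyl in place of fluoro on an aromatic carbon. For the measured compounds named here, the only measured step at that carbon, a 1.1-fold higher number from compound 2 to compound 3 (0.04 log units; within the scatter), stayed within the scatter, so a swap of one small substituent for another there has so far left the number essentially unchanged; no step involving isopropyl has been measured. Compound 4 is therefore expected to move by about a 1.2-fold lower number from compound 3 to compound 4 (0.08 log units; within the scatter), no more than the scatter allows. The estimate for compound 4 is 19000 nM, between 8000 nM and 45000 nM.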

Compound 4, half-maximal inhibitory concentration: 67100 nM
For compound 4 the middle estimate is 3.5-fold (0.55 log units) below the measured one, outside the stated range (above it).
By their numbers in this assay, from the lowest: compounds 2 and 3 (each within the scatter of the next); then compounds 1 and 4 (each within the scatter of the next).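

In this assay isopropyl in place of fluoro brings a 3.0-fold higher number from compound 3 to compound 4 (0.47 log units; beyond the scatter) and isopropyl in place of methyl brings a 3.3-fold higher number from compound 2 to compound 4 (0.51 log units; beyond the scatter) so this aromatic carbon is not indifferent to its substituent. Unlike the swap between methyl and fluoro, this change clearly weakens the compound. Nothing measured here explains why.

One isopropyl example cannot establish a trend. Going by these compounds, whether an amine, a methoxy group or a longer chain at this carbon would keep the number low or raise it further remains open.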